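Swapping chloro for methoxy on a bis-thiophene amidine

This account rests on a few compounds, and the source may have more. Where it says the series, first, only, none or still open, it means among the compounds named here.

Three amidines were tested in an ADME assay on cells (Erythrocyte, Homo sapiens) for activation, read by hemolysis, with a stated time of 30 min, tested at 5 mM; on this read-out lower numbers stand for a weaker effect and higher numbers for a stronger effect at the one concentration tested. Compound 1 `N=C(N)c1ccc(-c2ccc(-c3ccc(Cl)cc3)s2)s1` gives 49%, the highest of the three numbers. Compound 3 `COc1ccc(-c2ccc(-c3ccc(C(=N)N)o3)o2)cc1` gives 36.3%, which is the nearest and still lies beyond the scatter below compound 1. Compound 2 `N=C(N)c1ccc(-c2ccc(-c3ccc4ccccc4c3)s2)s1` gives 13%, the furthest below. Compound 4 `COc1ccc(-c2ccc(-c3ccc(C(=N)N)s3)s2)cc1` has not yet been measured in this assay. It differs from compound 1 by methoxy in place of chloro on an aromatic carbon. Among the compounds with values here, since no measured pair isolates this exchange, the step from compound 1 to compound 4 is expected to be a small decrease of a number 9 percentage points lower from compound 1 to compound 4 (within the scatter), not beyond the scatter, in part because compound 3 with the same methoxy gives 36.3%. Compound 4 is therefore estimated at 40%, within 22% to 58%.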

Compound 4, a percentage reported as activity, at one concentration (the size of the read-out at that concentration, not a potency): 63.7%
For compound 4 the middle estimate is 23.7 percentage points below the measured one; measured number outside the range, above it.
By their numbers in this assay, from the lowest: compound 2; then compound 3; then compound 1; then compound 4.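

In this assay, methoxy in place of chloro on an aromatic carbon gives a number 14.7 percentage points higher from compound 1 to compound 4 (beyond the scatter), so the group at this place, para to a large group, affects the read-out on this core. Within the data shown here, this pair is the first to isolate the exchange, as the earlier compounds differ from each other in more than one place. Nothing available gives a reason for the rise. On these data alone, whether an amine or a carboxylic acid at this place would raise or lower the number remains open, as does whether the same exchange would act alike on the core of compound 3.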